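The source may report more compounds than this note shows. Statements on the series, on what has been measured and on what is new or still open speak of the compounds shown alone.

Compound 1 `O=C(CSc1cccc(O)c1)Nc1ccc2nc(NC(=O)c3ccccc3)sc2c1` is the reference point for this step in a functional assay on U2OS cells (Homo sapiens) for antiproliferative activity, read by MTT assay, with a stated time of 72 h; on this read-out higher numbers stand for weaker inhibition and lower numbers for stronger inhibition. In this assay compound 1 gives > 100000 nM, which is a limit of the assay and not a number. Compound 2 `Cn1c(CNC(=O)c2cccs2)nnc1SCC(=O)Nc1ccc(Cl)cc1` gives > 100000 nM, also a limit. Compound 3 `Cn1c(CNC(=O)c2cccs2)nnc1SCC(=O)Nc1cccc(Cl)c1` gives > 100000 nM, again a limit.

Compound 4 `CCCC(=O)Nc1nc2ccc(NC(=O)CSc3cccc(O)c3)cc2s1` keeps the core of compound 1 and carries this change: propyl in place of phenyl on a carbonyl carbon. In other words, benzamido gives way to (propylcarbonyl)amino.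

For the measured compounds named here, the only measured step, a step that the two limits leave unreadable from compound 2 to compound 3, concerns a different change in a different structure and offers no size to carry over. With compound 1 among them, the compounds stand at the limit of > 100000 nM in this assay, at which 3 of the 3 values shown sit, so no readable step bears on this change. A step beyond the scatter is therefore not expected in this assay, and no direction can be assigned. The expected step is a number no higher from compound 1 to compound 4 (the limit leaves the size open). For compound 4 the estimated value is 100000 nM, with an expected range of 30000 nM to 300000 nM.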

Compound 4, half-maximal inhibitory concentration: 10100 nM
The estimate for compound 4 lay 9.9-fold (1.00 log units) above the measured number; the whole stated range lies above it.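

In this assay, the place on the carbonyl carbon is one where a change can be read: propyl in place of phenyl gives an at least 9.9-fold lower number from compound 1 to compound 4 (0.99 log units; beyond the scatter). Compound 4 is the first compound shown with a number and not a limit: the limit of > 100000 nM in this assay, at which 3 of the 4 values shown sit. Compound 1 gives > 100000 nM, which is a limit and not a number.

The compounds shown do not separate the effect of chain length from the loss of the aromatic ring, and a butyl or pentyl chain and a cyclohexyl ring would be the direct tests at this place. As far as these compounds go, the full size of the step also stays open, as does the response to a chain ending in an amine or a carboxylic acid.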